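A few compounds are considered here, and "the series" means these few. Any claim that something is new, unique, unknown or untested is made for them only; others in the source may bear on it.

In a functional assay on EBC-1 cells (Homo sapiens) for antiproliferative activity, with a stated time of 72 h (a lower number here means a stronger inhibitor, a higher number a weaker inhibitor), compound 1 (`Cn1cc(-c2cc(C(F)(F)F)c3ncc(Cc4ccc5ncccc5c4)n3c2)cn1`) is recorded as "not determined" (no result reported) and offers no number for comparison. Compound 2 (`CNC(=O)c1cccc(-c2cc(F)c3ncc(Cc4ccc5ncccc5c4)n3c2)c1`) gives 400 nM and compound 3 (`O=C(NCCCN1CCCC1)c1ccc(-c2cc(F)c3ncc(Cc4ccc5ncccc5c4)n3c2)cc1F`) gives 161 nM as the lower of the two numbers, a gap beyond the usual scatter. Compound 4 (`O=C(NC1CCOCC1)c1ccc(-c2cc(F)c3ncc(Cc4ccc5ncccc5c4)n3c2)cc1F`) differs from compound 3 by one change (oxan-4-yl in place of 3-(pyrrolidin-1-yl)propyl on an amide-type nitrogen): oxan-4-yl in place of 3-(pyrrolidin-1-yl)propyl on an amide-type nitrogen. Among the measured compounds shown here, no measured pair shows this change alone. Compound 2, which also lacks the 3-(pyrrolidin-1-yl)propyl group but differs elsewhere too, gives 400 nM and so points towards a higher number. A modest step towards weaker inhibition is therefore expected in this assay (a 2.2-fold higher number from compound 3 to compound 4 (0.34 log units; beyond the scatter)) on thin evidence. For compound 4 the estimated value is 350 nM and the expected range runs from 120 nM to 1000 nM in this measurement.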

Compound 4, half-maximal inhibitory concentration: 70.5 nM
Estimate against measurement, compound 4: 5.0-fold (0.70 log units) above, outside the stated range (below it).
By their numbers in this assay, from the lowest: compound 4; then compound 3; then compound 2.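

Among the compounds shown here, with oxan-4-yl in place of 3-(pyrrolidin-1-yl)propyl on the amide-type nitrogen, this assay shows a 2.3-fold lower number from compound 3 to compound 4 (0.36 log units; beyond the scatter) and so gives the first reading of this change alone. The longer chain ending in a pyrrolidine ring is therefore not required for activity in this pair, and the smaller oxygen-containing ring serves better here. Nothing measured here explains the step. On these data alone, whether the ring oxygen matters remains open: a cyclohexyl group, or a piperidin-4-yl group with an amine in the oxygen's place, on the same nitrogen would test it.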